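A ring swap on the weaker of two inhibitors

A few compounds are considered here, and "the series" means these few. Any claim that something is new, unique, unknown or untested is made for them only; others in the source may bear on it.

For the measured compounds named here, in a functional assay on Shh Light II cells (Mus musculus) for inhibition, read by a luciferase reporter (a higher number here means a weaker inhibitor, a lower number a stronger inhibitor), compound 1 `O=C(NC1CCNCC1)N1CCC(c2nc(-c3ccc4ccccc4n3)no2)CC1` gives 2500 nM and holds the higher of the two numbers so far, which makes it the weaker inhibitor of the pair. Compound 2 `Cn1c(-c2noc(C3CCN(C(=O)NC4CCCCC4)CC3)n2)nc2ccccc21` has a different core and gives 89 nM in the same test. Compound 3 `O=C(NC1CC[S+]([O-])CC1)N1CCC(c2nc(-c3ccc4ccccc4n3)no2)CC1` keeps the core of compound 1, but the piperidin-4-yl group on the amide-type nitrogen is replaced, and a group of 7 heavy atoms (5 carbon, 1 oxygen, 1 sulfur; one six-membered non-aromatic ring with 1 hetero atom) in place of a group of 6 heavy atoms (5 carbon, 1 nitrogen; one six-membered non-aromatic ring with 1 hetero atom), on an amide-type nitrogen is the whole difference. Going by the values given here, no measured pair shows this change on its own, so any forecast is loose. Compound 2 at 89 nM carries no piperidin-4-yl group, which suggests that losing this group need not cost activity. A moderate gain is expected, with a 3.6-fold lower number from compound 1 to compound 3 (0.55 log units; beyond the scatter) as the estimated step towards a lower number. For compound 3 the expected value is 700 nM within an estimated range of 150 nM to 3000 nM in this assay here.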

Compound 3, half-maximal inhibitory concentration: 850 nM
Beside the measured number, compound 3's estimate is 1.2-fold (0.08 log units) below it, within the range that was stated.
By their numbers in this assay, from the lowest: compound 2; then compound 3; then compound 1.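

For the compounds shown here, the first step that changes one place alone shows that this position, on an amide-type nitrogen, can accept a different ring: in this assay the swap of the piperidin-4-yl group for the sulfur-bearing six-membered ring gives a 2.9-fold lower number from compound 1 to compound 3 (0.47 log units; beyond the scatter) on an unchanged core. The entering group counts 0 hydrogen-bond donors against 1 for the group that leaves, so a donor on this ring is not required for inhibition on this core. No measurement shown here explains the gain.

A single swap cannot tell whether the gain comes from losing the ring nitrogen or from adding the sulfur and its oxygen. A tetrahydropyran-4-yl ring on the same nitrogen of the core of compound 1, with a plain ring oxygen in place of that sulfur and its oxygen, would help to separate the two.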